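Amide for piperidine on the side chain of compound 3

A few compounds are considered here, and "the series" means these few. Any claim that something is new, unique, unknown or untested is made for them only; others in the source may bear on it.

The series shares one core, carried here by compound 3 `Cn1ncc(Cl)c1-c1cc(C(=O)N[C@@H]2CN[C@H](CCN3CCCCC3)C[C@H]2c2ccc(Cl)c(Cl)c2)oc1Cl`. In an assay for inhibition of RAC-alpha serine/threonine-protein kinase (Homo sapiens), read by HTRF, with a stated time of 1 h (a higher number here means a weaker inhibitor, a lower number a stronger inhibitor), compound 3 gives 5.65 nM, the second highest of the three numbers, with all three lying within the scatter of one another. Compound 1 `Cn1ncc(Cl)c1-c1cc(C(=O)N[C@@H]2CN[C@H](CC(O)CO)C[C@H]2c2ccc(Cl)c(Cl)c2)oc1Cl` gives 3.79 nM in this assay, and compound 2 `Cn1ncc(Cl)c1-c1cc(C(=O)N[C@@H]2CN[C@H](CCN3CCC(O)CC3)C[C@H]2c2ccc(Cl)c(Cl)c2)oc1Cl` gives 5.99 nM. The step of a 1.5-fold higher number from compound 1 to compound 3 (0.17 log units; within the scatter) and the step of a 1.1-fold lower number from compound 2 to compound 3 (0.03 log units; within the scatter) both stay within the scatter, as does the step of a 1.6-fold higher number from compound 1 to compound 2 (0.20 log units; within the scatter).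

Compound 4 `Cn1ncc(Cl)c1-c1cc(C(=O)N[C@@H]2CN[C@H](CC(N)=O)C[C@H]2c2ccc(Cl)c(Cl)c2)oc1Cl` has not been measured. It differs from compound 3 in one place: carbamoyl in place of (piperidin-1-yl)methyl on a saturated chain carbon bound to a saturated ring carbon. The measured steps bear on this directly, since compound 1 carries a small polar group with two hydroxyls at the same position and compound 3 the larger saturated ring, and the step of a 1.5-fold higher number from compound 1 to compound 3 (0.17 log units; within the scatter) was within the scatter; the further swap in a 1.1-fold lower number from compound 2 to compound 3 (0.03 log units; within the scatter) also left the number unchanged beyond the scatter. This position therefore appears to accept groups of quite different size and polarity without a step beyond the scatter, on the evidence of these three compounds alone.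

Compound 4 is accordingly expected to show a step of a 1.1-fold lower number from compound 3 to compound 4 (0.05 log units; within the scatter) in this assay, no more than the scatter. The estimate for compound 4 is 5 nM, with a range from 1.5 nM to 16 nM.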

Compound 4, half-maximal inhibitory concentration: 3.24 nM
Compound 4: the middle estimate sits 1.5-fold (0.19 log units) above what was measured; the range from low to high includes it.
By their numbers in this assay, from the lowest: compounds 4, 1, 3 and 2 (each within the scatter of the next).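

The carbamoyl group is the smallest of the four groups at this place, on a saturated chain carbon bound to a saturated ring carbon, and in this assay it gives a 1.7-fold lower number from compound 3 to compound 4 (0.24 log units; within the scatter) when it takes the place of (piperidin-1-yl)methyl. Set against the ring that carries a hydroxy group, it gives a 1.8-fold lower number from compound 2 to compound 4 (0.27 log units; within the scatter), and set against the open-chain diol, it gives a 1.2-fold lower number from compound 1 to compound 4 (0.07 log units; within the scatter). The earlier compounds shown here showed tolerance only among a diol chain and two piperidine rings, whereas these steps extend it to a group of 3 heavy atoms with a carbonyl, so all four compounds now lie within the scatter of one another and none of these changes separates them.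

The compounds shown leave open whether a carboxylic acid, a primary amine, a bare methyl or a longer chain ending in carbamoyl at this place would also stay within the scatter, or whether some group would move the number beyond it. Nothing given here speaks to why these four groups read alike in this assay.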